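Thiazolotriazole anilides: from compound 3 to compound 4

A few compounds are considered here, and "the series" means these few. Any claim that something is new, unique, unknown or untested is made for them only; others in the source may bear on it.

Measured so far:
compound 1 `CCc1ccc(-c2nn3cc(-c4cccc(N)c4)nc3s2)cc1` 22000 nM
compound 2 `C=C(Br)C(=O)Nc1cccc(-c2cn3nc(-c4ccc(CC)cc4)sc3n2)c1` 3400 nM
compound 3 `C=C(Br)C(=O)Nc1cccc(-c2cn3nc(-c4ccc(F)cc4)sc3n2)c1` 830 nM

All three numbers come from a functional assay on CCRF-CEM cells (Homo sapiens) for inhibition, read by cell counting, with a stated time of 3 days; a lower number here means a stronger inhibitor, a higher number a weaker inhibitor. Compound 3 holds the lowest number of the three; compound 2 sits nearest, and compound 1 furthest. The two steps known so far are a 6.5-fold lower number from compound 1 to compound 2 (0.81 log units; beyond the scatter) and a 4.1-fold lower number from compound 2 to compound 3 (0.61 log units; beyond the scatter), both beyond the scatter and both in the same direction.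

Compound 4 `C=C(Br)C(=O)Nc1cccc(-c2cn3nc(Cc4cccc(OC)c4)sc3n2)c1` is not yet measured. It differs from compound 3 in one place: 3-methoxybenzyl in place of 4-fluorophenyl on an aromatic carbon. For the measured compounds named here, of the measured steps, only the one from compound 2 to compound 3 touches this same aromatic carbon, and there a single substituent swap on the pendant ring already moved this assay by a modest but real amount. The change to compound 4 is larger in kind, as a benzyl group with a methoxy substituent replaces a directly attached fluorophenyl ring; nothing measured shows what such a change does here, so the direction is uncertain.

The working expectation is that compound 4 gives 2500 nM in this assay, with a range of 500 nM to 12000 nM. That estimate means a step of a 3.0-fold higher number from compound 3 to compound 4 (0.48 log units; beyond the scatter), expected to be a loss relative to compound 3, with wide uncertainty in both directions.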

Compound 4, half-maximal inhibitory concentration: 3100 nM
Estimate against measurement, compound 4: 1.2-fold (0.09 log units) below, and the stated range covers the measured number.
By their numbers in this assay, from the lowest: compound 3; then compounds 4 and 2 (each within the scatter of the next); then compound 1.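

In this assay, the aromatic carbon next to the ring sulfur tolerates more than a directly attached phenyl ring, but the swap to 3-methoxybenzyl gives a 3.7-fold higher number from compound 3 to compound 4 (0.57 log units; beyond the scatter), so the 4-fluorophenyl group of compound 3 is not matched by this benzyl group. Against the 4-ethylphenyl group the same benzyl group gives a 1.1-fold lower number from compound 2 to compound 4 (0.04 log units; within the scatter), so at this position two quite different groups, one with a ring attached directly and one with a ring set off by a benzyl carbon and carrying a methoxy group, cannot be told apart by this read-out. Nothing available gives a measured property or a reason that bears on either step.

The step from compound 3 to compound 4 changes the link and the ring substituent together, so the share of each stays unresolved; a 4-fluorobenzyl or a 3-methoxyphenyl group at this carbon would separate them. Also open, going by these compounds, is how this position responds to groups of another kind, such as an amine or a carboxylic acid on the pendant ring, or to a longer chain in place of the benzyl carbon.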